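Amide side-chain variation on the shared core

The compounds below may be only part of what the source reports. "The series", "measured", "known", "first", "only" and "open" are said of these compounds alone.

Measured in an ADME assay on BJ cells (Homo sapiens) for inhibition, with a stated time of 72 h; on this read-out lower numbers stand for an effect already at smaller amounts and higher numbers for an effect only at larger amounts of compound:
- compound 1 `C/C=C/C(=O)Nc1cccc(-c2nc3ccccc3s2)c1`: > 25000 nM (a limit)
- compound 2 `CN(C)CCC(=O)Nc1cccc(-c2nc3ccccc3s2)c1`: > 25000 nM (a limit)

Compound 1 reaches only a limit in this assay, > 25000 nM. Compound 2 likewise reaches only a limit, > 25000 nM. Both values sit at the limit of > 25000 nM in this assay, at which 2 of the 2 values shown sit, so the step that the two limits leave unreadable from compound 1 to compound 2 cannot be sized. Compound 3 `CC(C)(CCl)C(=O)Nc1cccc(-c2nc3ccccc3s2)c1` differs from compound 2 by 1-(chloromethyl)-1-methylethyl in place of 2-(dimethylamino)ethyl on a carbonyl carbon. No readable step bears on this change, so no direction can be drawn from the measured pair. Compound 3 is expected to remain at the limit, estimated at 25000 nM with a range from 12000 nM to 50000 nM. The step of a number no higher from compound 2 to compound 3 (the limit leaves the size open) is accordingly expected to stay unreadable.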

Compound 3, half-maximal effective concentration: > 25000 nM
Compound 3: a limit, no number (the forecaster's own chance of this, stated with the estimate: 80%); the middle value lies on the limit itself.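

Among these compounds, compound 3 also gives only a limit, as do compound 1 and compound 2, so no step among the three can be read: the limit of > 25000 nM in this assay, at which 3 of the 3 values shown sit. The compounds shown leave open which amide side chain, if any, reaches a measurable value in this assay.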